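Trifluoromethyl in place of methylpiperazine on the pyridazinyl amide

The source may report more compounds than this note shows. Statements on the series, on what has been measured and on what is new or still open speak of the compounds shown alone.

In an assay on Sf9 cells for inhibition of Leucine-rich repeat serine/threonine-protein kinase 2 (Homo sapiens), read by TR-FRET, with stated times of 30 min and 2 h (a lower number here means a stronger inhibitor, a higher number a weaker inhibitor), compound 3 `CN1CCN(c2ccc(OCc3ccccc3)c(C(=O)Nc3ccnnc3)c2)CC1` gives 12.6 nM, the low end of the three numbers; compound 1 `O=C(Nc1cccc(Cl)c1)c1cc(C(F)(F)F)ccc1OCc1ccccc1` with 25.1 nM lies within the scatter of it, while compound 2 `CN1CC2(CCN(c3ccc(OCc4ccccc4)c(C(=O)Nc4ccnnc4)c3)CC2)C1` with 63.1 nM sits beyond, shown by a 5.0-fold lower number from compound 2 to compound 3 (0.70 log units; beyond the scatter). Compound 4 `O=C(Nc1ccnnc1)c1cc(C(F)(F)F)ccc1OCc1ccccc1` carries trifluoromethyl in place of 4-methylpiperazin-1-yl on an aromatic carbon. Going by the values given here, no measured step exchanges an amine for trifluoromethyl on this ring; the only step at that carbon, from compound 2 to compound 3, swaps one amine for another and is modest. Compound 1 already pairs trifluoromethyl with the same benzyloxy core and its value sits within the scatter of compound 3, so a step no larger than the scatter is expected for this assay, as a 2.0-fold higher number from compound 3 to compound 4 (0.30 log units; within the scatter). Compound 4 is therefore estimated at 25 nM, within 8 nM to 80 nM.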

Compound 4, half-maximal inhibitory concentration: 15.9 nM
Compound 4: the middle estimate sits 1.6-fold (0.20 log units) above what was measured, within the range that was stated.
By their numbers in this assay, from the lowest: compounds 3, 4 and 1 (each within the scatter of the next); then compound 2.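

In this assay, the amine at this aromatic carbon proves dispensable: trifluoromethyl, with no ring and no hydrogen-bond acceptors, stays within the scatter of 4-methylpiperazin-1-yl (a 1.3-fold higher number from compound 3 to compound 4 (0.10 log units; within the scatter)). Trifluoromethyl also holds its separation from the larger amine of compound 2 (a 4.0-fold lower number from compound 2 to compound 4 (0.60 log units; beyond the scatter)), and with it in place, pyridazin-4-yl and 3-chlorophenyl on the amide-type nitrogen cannot be told apart (a 1.6-fold lower number from compound 1 to compound 4 (0.20 log units; within the scatter)). No measurement at hand explains these steps. As far as these compounds go, whether a nitrile, a carboxylic acid or a longer chain at this carbon stays in the same range remains open. So does the value with hydrogen alone there.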